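Adding a Pyridin-2-yl Ring: Expected Half-Life of Compound 3

The compounds below may be only part of what the source reports. "The series", "measured", "known", "first", "only" and "open" are said of these compounds alone.

Compound 1, `CCCCN(c1nc2c(C(=O)NS(C)(=O)=O)cccc2o1)[C@H](C)c1ccc(-c2ccccc2-c2nnn[nH]2)cc1`: 2.7 h
Compound 2, `CCCCN(c1nc2ccccc2o1)[C@H](C)c1ccc(-c2ccccc2-c2nnn[nH]2)cc1`: 3.2 h

Both compounds were examined in an ADME assay on the whole organism (Macaca fascicularis) for metabolic stability, read by LC-MS, using cassette dosing, at a dose of 1 mg/kg by the oral route; on this read-out higher numbers stand for a longer-lived compound and lower numbers for a shorter-lived compound. Compound 1 gives 2.7 h and compound 2 gives 3.2 h; the one step between them, a 1.2-fold higher number from compound 1 to compound 2 (0.07 log units; within the scatter), lies within the scatter, so compound 2 and compound 1 stand together on the numbers shown, with no difference that can be read as real.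

Compound 3, `CCCCN(c1nc2c(-c3ccccn3)cccc2o1)[C@H](C)c1ccc(-c2ccccc2-c2nnn[nH]2)cc1`, has not been measured in this assay. It differs from compound 2 by pyridin-2-yl in place of hydrogen on an aromatic carbon. Going by the values given here, no measured step bears on this change: the only step known, from compound 1 to compound 2, concerns a different group at the same kind of place and stayed within the scatter. With nothing to point in either direction, compound 3 is expected to show no step beyond the scatter, a 1.1-fold lower number from compound 2 to compound 3 (0.03 log units; within the scatter). Compound 3 is therefore estimated at 3 h, within 1.5 h to 6 h.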

Compound 3, half-life: 5.9 h
Compound 3: middle estimate off by 2.0-fold (0.29 log units), on the low side; low and high end bracket the measured number.
By their numbers in this assay, from the lowest: compounds 1, 2 and 3 (each within the scatter of the next, the first and the last beyond it).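

In this assay the pyridin-2-yl ring on this aromatic carbon gives a 1.8-fold higher number from compound 2 to compound 3 (0.27 log units; within the scatter) and so cannot be told apart from hydrogen, just as (methylsulfonyl)carbamoyl could not be before. The new information lies in the comparison of the two larger groups: this place now shows a difference that can be read as real, a 2.2-fold higher number from compound 1 to compound 3 (0.34 log units; beyond the scatter) for pyridin-2-yl in place of (methylsulfonyl)carbamoyl, though the step is modest. No measurement on hand accounts for this difference.

The compounds shown leave open whether a phenyl ring, a carboxylic acid or an amine on this carbon would fall nearer compound 1 or compound 3. They also leave open whether pyridin-2-yl would give a similar number on another aromatic carbon of the shared core.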